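Aryl swap on the ring amine of compound 2

The source may report more compounds than this note shows. Statements on the series, on what has been measured and on what is new or still open speak of the compounds shown alone.

Measured so far in a functional assay on MDA-MB-231 cells (Homo sapiens) for inhibition, read by sulforhodamine B assay; on this read-out lower numbers stand for stronger inhibition and higher numbers for weaker inhibition:
compound 1 `COC(=O)CC/C(C)=C/Cc1c(OC)c(C)c2c(c1OCC#CCN1CCN(C(c3ccccc3)c3ccccc3)CC1)C(=O)OC2` — compound 1 gives > 50000 nM, a limit of the assay and not a number.
compound 2 `COC(=O)CC/C(C)=C/Cc1c(OC)c(C)c2c(c1OCC#CCN1CCN(c3ccc(C#N)cc3)CC1)C(=O)OC2` — compound 2 gives > 50000 nM, likewise a limit of the assay.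
compound 3 `CCCCNc1ccc(CC#CCOc2c(C/C=C(\C)CCC(=O)OC)c(OC)c(C)c3c2C(=O)OC3)cc1` — compound 3 gives 19800 nM.

Compound 2 therefore stands at the limit of > 50000 nM in this assay, at which 2 of the 3 values shown sit, with no number of its own. Compound 3 alone returns a number, and that number is weak. Among the compounds with values here, no two of the three compounds differ in only one place, so no measured step exists in this set and nothing is known about the effect of changing the group on the ring amine nitrogen.

Compound 4 `COC(=O)CC/C(C)=C/Cc1c(OC)c(C)c2c(c1OCC#CCN1CCN(c3ccccc3F)CC1)C(=O)OC2` differs from compound 2 in one place:

2-fluorophenyl in place of 4-cyanophenyl on an amine nitrogen in a ring

Within the data shown here, with no measured step to rest on, the expectation is a step of no size beyond the scatter, and the most likely outcome is again a limit rather than a number. Compound 4 is expected at 50000 nM, within 20000 nM to 120000 nM. That estimate means an expected step of a number no higher from compound 2 to compound 4 (the limit leaves the size open).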

Compound 4, half-maximal inhibitory concentration: > 50000 nM
Compound 4: a limit, no number (the forecaster's own chance of this, stated with the estimate: 65%); the middle value lies on the limit itself.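

Compound 2 and compound 4 each return only a limit of the assay and not a number, so no step can be read for 2-fluorophenyl in place of 4-cyanophenyl: the limit of > 50000 nM in this assay, at which 3 of the 4 values shown sit. The compounds shown leave open whether any group on this ring amine nitrogen changes inhibition.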